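A few compounds are considered here, and "the series" means these few. Any claim that something is new, unique, unknown or untested is made for them only; others in the source may bear on it.

Measured compounds in a functional assay with Homo sapiens as the target; on this read-out higher numbers stand for weaker inhibition and lower numbers for stronger inhibition:
Compound 1 `CC(C)[C@H](NC(=O)COc1cccc2ccccc12)C(=O)N[C@@H](CC(=O)O)C(=O)COc1ccccc1` gives 11200 nM.
Compound 2 `CC(C)[C@H](NC(=O)COc1cccc2ccccc12)C(=O)N[C@@H](CC(=O)O)C(=O)COc1ccc(C#N)cc1` gives 26700 nM.
Compound 3 `CC(C)[C@H](NC(=O)COc1cccc2ccccc12)C(=O)N[C@@H](CC(=O)O)C(=O)COc1cc(F)cc(F)c1` gives 15900 nM.

On these numbers compound 2 stands highest of the three, which on this read-out means the weakest inhibition: the step of a 2.4-fold higher number from compound 1 to compound 2 (0.38 log units; beyond the scatter) lies beyond the scatter, while its gap to compound 3, a 1.7-fold lower number from compound 2 to compound 3 (0.23 log units; within the scatter), stays within the scatter. Compound 4 `CC(C)[C@H](NC(=O)COc1cccc2ccccc12)C(=O)N[C@@H](CC(=O)O)C(=O)COc1c(F)cc(F)cc1F` has not been measured. It differs from compound 2 in one place: 2,4,6-trifluorophenyl in place of 4-cyanophenyl on an oxygen on a saturated carbon. For the measured compounds named here, three measured steps bear on this change. The step that swaps the same 4-cyanophenyl for a fluorinated phenyl gives a 1.7-fold lower number from compound 2 to compound 3 (0.23 log units; within the scatter); the step in which cyano replaces hydrogen gives a 2.4-fold higher number from compound 1 to compound 2 (0.38 log units; beyond the scatter); and the step that puts two fluorines on a plain phenyl gives a 1.4-fold higher number from compound 1 to compound 3 (0.15 log units; within the scatter). Going by the values given here, the only step beyond the scatter is the one that introduces the cyano group, and the fluorine steps stay within it. A modestly lower number is expected for compound 4, about a 1.9-fold lower number from compound 2 to compound 4 (0.28 log units; within the scatter), because the closest measured step was a 1.7-fold lower number from compound 2 to compound 3 (0.23 log units; within the scatter). Compound 4 is therefore estimated at 14000 nM, with a range from 6000 nM to 35000 nM.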

Compound 4, half-maximal inhibitory concentration: 14900 nM
Compound 4: the middle estimate sits 1.1-fold (0.03 log units) below what was measured; the measured number falls inside the stated range.
By their numbers in this assay, from the lowest: compounds 1, 4, 3 and 2 (each within the scatter of the next, the first and the last beyond it).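

In this assay, replacing the 4-cyanophenyl on this oxygen with 2,4,6-trifluorophenyl gives a 1.8-fold lower number from compound 2 to compound 4 (0.25 log units; within the scatter) and so adds a second fluorinated group that cannot be told apart from the 4-cyanophenyl compound. The new compound also cannot be separated from either of the other two, with a 1.1-fold lower number from compound 3 to compound 4 (0.03 log units; within the scatter) for the change from 3,5-difluorophenyl and a 1.3-fold higher number from compound 1 to compound 4 (0.12 log units; within the scatter) for the change from plain phenyl. Across these four compounds, the plain phenyl, the two fluorinated phenyl groups and the 4-cyanophenyl all give similar numbers, and the only gap that clears the scatter remains a 2.4-fold higher number from compound 1 to compound 2 (0.38 log units; beyond the scatter) even though compound 4 now sits within the scatter of both ends.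

On these data alone, it remains open whether an amine or a carboxylic acid on this phenyl ring, or a longer chain in place of the ring, would shift the number beyond the scatter. No other measurement shown here bears on these steps, so the numbers give no account of what lies behind them.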